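The source may hold more compounds than are shown below. What is called first, only, known or untested is meant among the compounds shown, and "the series" means these compounds.

Within the data shown here, compound 2, with the structure `CC1CC/C(=N\Nc2ccc(C(F)(F)F)cc2)c2ncc(C(=O)O)c(=O)n21`, stands at the higher of the two numbers measured so far in a functional assay on the whole organism for inhibition, with Rattus norvegicus as the target (on this read-out lower numbers stand for an effect already at smaller amounts and higher numbers for an effect only at larger amounts of compound), giving 38.6 umol/kg. Among the measured compounds shown here, its only neighbour, compound 1 with the structure `CC1CC/C(=N\Nc2ccc(F)cc2)c2ncc(C(=O)O)c(=O)n21`, gives 12.2 umol/kg in this assay, and the one measured step, a 3.2-fold higher number from compound 1 to compound 2 (0.50 log units; beyond the scatter), separates the two. Compound 3, with the structure `CC(C)c1ccc(N/N=C2\CCC(C)n3c2ncc(C(=O)O)c3=O)cc1`, is not yet measured; it differs from compound 2 in one place: isopropyl in place of trifluoromethyl on an aromatic carbon. The measured step bears on this change only loosely, since it shows that an exchange at this same aromatic carbon moved the number by a modest amount, but it says nothing directly about isopropyl. With so thin a basis, a step of a 1.3-fold lower number from compound 2 to compound 3 (0.11 log units; within the scatter) is expected for compound 3, within the usual scatter. Compound 3 is therefore estimated at 30 umol/kg in this assay, with a range from 10 umol/kg to 90 umol/kg.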

Compound 3, dose for 50% inhibition: 2.4 umol/kg
For compound 3 the middle estimate is 13-fold (1.10 log units) above the measured one; the measured number lies below the stated range.
By their numbers in this assay, from the lowest: compound 3; then compound 1; then compound 2.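

This aromatic carbon turns out to be far more sensitive than the first measured exchange suggested: in this assay, isopropyl in place of trifluoromethyl gives a 16-fold lower number from compound 2 to compound 3 (1.21 log units; beyond the scatter), a large step where the earlier exchange was only modest. Isopropyl also improves on fluoro, with a 5.1-fold lower number from compound 1 to compound 3 (0.71 log units; beyond the scatter), so compound 3 has the lowest number of the three and the all-carbon isopropyl is the best of these three groups at this position. No measurement shown here explains why the number drops so far with isopropyl.

As far as these compounds go, whether other all-carbon groups, such as ethyl or tert-butyl, would give a still lower number remains open. So does the effect of groups containing oxygen or nitrogen at this carbon, such as methoxy or an amine.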